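Methoxy in Place of Carbamoyl on the Alkyne Chain

A few compounds are considered here, and "the series" means these few. Any claim that something is new, unique, unknown or untested is made for them only; others in the source may bear on it.

Compound 2 `CC(C)(CC#Cc1c(Cl)c2c(Cl)cc(C(N)=O)nc2n1[C@H]1CCCNC1)C(N)=O` gives 269 nM in a functional assay on KG-1 cells (Homo sapiens) for antiproliferative activity (on this read-out higher numbers stand for an effect only at larger amounts of compound and lower numbers for an effect already at smaller amounts), the higher of the two numbers measured there. Compound 1 `CC1(C#Cc2c(Cl)c3c(Cl)cc(C(N)=O)nc3n2[C@H]2CCCNC2)COC1` gives 119 nM in this assay, and the step of a 2.3-fold higher number from compound 1 to compound 2 (0.35 log units; beyond the scatter) is modest but beyond the scatter. Compound 3 `COC(C)(C)CC#Cc1c(Cl)c2c(Cl)cc(C(N)=O)nc2n1[C@H]1CCCNC1` has not yet been measured. It differs from compound 2 in one place: methoxy in place of carbamoyl on a saturated chain carbon bound to three saturated chain carbons. Going by the values given here, no measured step covers this exchange; the only step available, a 2.3-fold higher number from compound 1 to compound 2 (0.35 log units; beyond the scatter), concerns a different group on the triple-bonded carbon and gives no direct guide to swapping a carbamoyl for a methoxy. With nothing bearing on the change, a step of a 1.2-fold lower number from compound 2 to compound 3 (0.09 log units; within the scatter) is expected, not beyond the scatter. Compound 3 is therefore estimated at 220 nM in this assay, with a range from 70 nM to 700 nM.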

Compound 3, half-maximal effective concentration: 172 nM
The estimate for compound 3 lay 1.3-fold (0.11 log units) above the measured number; low and high end bracket the measured number.
By their numbers in this assay, from the lowest: compounds 1, 3 and 2 (each within the scatter of the next, the first and the last beyond it).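

In this assay, methoxy in place of carbamoyl on a saturated chain carbon bound to three saturated chain carbons gives a 1.6-fold lower number from compound 2 to compound 3 (0.19 log units; within the scatter) and shows that, in this pair, the number stays within the scatter although carbamoyl carries a hydrogen-bond donor and methoxy carries none. 2-Methoxy-2-methylpropyl in place of 3-methyloxetan-3-yl gives a 1.4-fold higher number from compound 1 to compound 3 (0.16 log units; within the scatter) and so, unlike the 2-carbamoyl-2-methylpropyl chain of compound 2, stays within the scatter of compound 1. Nothing available explains these steps. The compounds shown leave open whether an amine, a carboxylic acid or a hydroxyl on that same chain carbon would also stay within the scatter of compound 3. They also leave open how an ethoxy group or a longer chain would read in this assay.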